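From Chloro to Fluoro on a Tolerated Compound

The compounds below may be only part of what the source reports. "The series", "measured", "known", "first", "only" and "open" are said of these compounds alone.

In a toxicity assay on THP-1 cells (Homo sapiens) for inhibition (a higher number here means that more compound is tolerated, a lower number that less compound is tolerated), compound 1 `Cn1c(-c2ccccc2)cnc1NC(=O)c1ccc(F)cc1` gives > 100000 nM, which is a limit of the assay. Compound 2 `Cn1c(-c2ccc(Cl)cc2)cnc1NC(=O)c1ccc(F)cc1` gives a true number, 37000 nM. Compound 3 `Cn1c(-c2cccc(Cl)c2)cnc1NC(=O)c1ccc(F)cc1` gives > 50000 nM, again only a limit. Compound 3 therefore has no exact value, and any step from it must be judged against that limit.

Compound 4 `Cn1c(-c2cccc(F)c2)cnc1NC(=O)c1ccc(F)cc1` carries fluoro in place of chloro on an aromatic carbon. The place is meta to a large group, so 3-chlorophenyl becomes 3-fluorophenyl. Going by the values given here, no measured step makes this exchange, so the chloro steps are the nearest guide. Adding one chloro gave an at least 2.7-fold lower number from compound 1 to compound 2 (0.43 log units; beyond the scatter). Adding the other gave a step that the two limits leave unreadable from compound 1 to compound 3. Moving the chloro gave an at least 1.3-fold higher number from compound 2 to compound 3 (0.13 log units; that floor lies within the scatter). The only readable drop among these is thus the one to compound 2, and it does not involve the group being exchanged. With compound 1 at > 100000 nM, a limit, nothing suggests that fluoro should lower the number, so no step beyond the scatter is expected in this assay. The expected change is a step that the limit leaves unreadable from compound 3 to compound 4. For compound 4 the estimated value is 70000 nM, with an expected range from 35000 nM to 140000 nM.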

Compound 4, half-maximal cytotoxic concentration: 58000 nM
Compound 4: the middle estimate sits 1.2-fold (0.08 log units) above what was measured; the measured number falls inside the stated range.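

The exchange of chloro for fluoro at this place, meta to a large group, cannot itself be read, because compound 3 carries only a limit of the assay: the limit of > 50000 nM in this assay, at which 1 of the 4 values shown sits. Going by these compounds alone, what compound 4 adds is the first true number in this assay for a compound with a halogen at this place, and going from 4-chlorophenyl to 3-fluorophenyl gives a 1.6-fold higher number from compound 2 to compound 4 (0.20 log units; within the scatter), so compound 2 and compound 4 cannot be told apart in this read-out. Fluoro in place of hydrogen gives an at least 1.7-fold lower number from compound 1 to compound 4 (0.23 log units; that floor lies within the scatter), and a floor of that size does not show that the fluoro group lowers the number, although it leaves room for a real drop.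

As far as these compounds go, whether chloro and fluoro truly differ at this place stays open, and so does the real size of the step from hydrogen to fluoro, since neither can be pinned down without exact values at the two limits. The compounds shown also leave open how an amine, a methoxy group or a carboxylic acid at this place would behave in this assay.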